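Fluorine patterns on a shared benzyl group

The source may report more compounds than this note shows. Statements on the series, on what has been measured and on what is new or still open speak of the compounds shown alone.

Three compounds with one shared core differ only in the aryl group bound to a saturated chain carbon on a ring amine nitrogen. In an assay on FRT cells for positive allosteric modulation of Cystic fibrosis transmembrane conductance regulator variant N1303K (Homo sapiens), in the presence of a further agent that is not named here (on this read-out higher numbers stand for an effect only at larger amounts of compound and lower numbers for an effect already at smaller amounts), compound 3 `COc1ccc2[nH]c3c(c2c1)CCNC31CCN(Cc2cc(F)c(F)c(F)c2)CC1` gives 2600 nM, the highest of the three numbers, though all lie within the scatter of one another; compound 2 `COc1ccc2[nH]c3c(c2c1)CCNC31CCN(Cc2ccc(F)cc2F)CC1` gives 2000 nM and compound 1 `COc1ccc2[nH]c3c(c2c1)CCNC31CCN(Cc2c(F)ccc(Cl)c2F)CC1` gives 1500 nM. The three steps among them are a 1.3-fold higher number from compound 1 to compound 2 (0.12 log units; within the scatter), a 1.7-fold higher number from compound 1 to compound 3 (0.24 log units; within the scatter) and a 1.3-fold higher number from compound 2 to compound 3 (0.11 log units; within the scatter). Compound 4 `COc1ccc2[nH]c3c(c2c1)CCNC31CCN(Cc2cccc(F)c2F)CC1` carries 2,3-difluorophenyl in place of 3,4,5-trifluorophenyl on a saturated chain carbon bound to an amine nitrogen in a ring. Because every earlier exchange of the fluorine pattern on this aryl group moved the read-out by no more than a 1.7-fold higher number from compound 1 to compound 3 (0.24 log units; within the scatter), no step beyond the scatter is expected, and the expected step is a 1.2-fold lower number from compound 3 to compound 4 (0.07 log units; within the scatter). Compound 4 is therefore estimated at 2200 nM, with a range from 1000 nM to 4500 nM.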

Compound 4, half-maximal effective concentration: 13600 nM
For compound 4 the middle estimate is 6.2-fold (0.79 log units) below the measured one, and the stated range ends below it.
By their numbers in this assay, from the lowest: compounds 1, 2 and 3 (each within the scatter of the next); then compound 4.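

In this assay, the aryl group on this saturated chain carbon proves sensitive to the fluorine pattern, which compounds 1, 2 and 3 did not show: the measurements give a 5.2-fold higher number from compound 3 to compound 4 (0.72 log units; beyond the scatter), a 6.8-fold higher number from compound 2 to compound 4 (0.83 log units; beyond the scatter) and a 9.1-fold higher number from compound 1 to compound 4 (0.96 log units; beyond the scatter). The number of fluorines alone does not sort these results, since 2,4-difluorophenyl and 2,3-difluorophenyl both carry two. The data shown offer no explanation for this.

From the compounds shown here alone, whether this shift is specific to the 2,3-difluorophenyl pattern remains open, as does how an unsubstituted phenyl, a 3-fluorophenyl or a pyridyl group would read at this place.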